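Swapping a hydroxy for a methyl in a thiosemicarbazone series

The source may hold more compounds than are shown below. What is called first, only, known or untested is meant among the compounds shown, and "the series" means these compounds.

Measured compounds:
- compound 1 `C=CCN(CC=C)C(=S)N/N=C(/C)c1ccc(O)cc1`: 216000 nM
- compound 2 `C=CCN(CC=C)C(=S)N/N=C\c1ccccc1O`: "not determined" (no result reported)
- compound 3 `C=CCN(CC=C)C(=S)N/N=C\c1ccc([N+](=O)[O-])o1`: < 213000 nM

In an ADME assay on Vero cells (Chlorocebus sabaeus) for cytotoxicity, read by MTT assay, with a stated time of 72 h (a lower number here means that less compound is tolerated, a higher number that more compound is tolerated), compound 1 gives 216000 nM. Compound 3 is reported only as a limit, < 213000 nM; this is the limit of < 213000 nM in this assay, at which 1 of the 3 values shown sits. Compound 2 stands apart: no number or limit is given for it in this assay, so where it sits against compound 1 and compound 3 cannot be said.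

Compound 4 `C=CCN(CC=C)C(=S)N/N=C\c1ccccc1C` differs from compound 2 by methyl in place of hydroxy on an aromatic carbon. With no measured step between any two of the shown compounds, the only anchor is compound 1, and no change beyond the usual scatter is expected from such a small swap. Compound 4 is therefore estimated at 200000 nM, with a likely range of 80000 nM to 500000 nM.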

Compound 4, half-maximal cytotoxic concentration: > 228000 nM
Compound 4 was reported as a limit; the forecaster's own chance of this, stated with the estimate: 35%; middle value at least 1.1-fold (0.05 log units) away from the limit.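

No step can be read from compound 2 to compound 4: compound 2 has no reported result, and compound 4 is given only as a limit, > 228000 nM. As far as these compounds go, what swapping hydroxy for methyl does in this assay therefore stays open.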